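Benzyloxy to Amino on a Side-Chain Carbonyl: Compound 4

This account rests on a few compounds, and the source may have more. Where it says the series, first, only, none or still open, it means among the compounds named here.

Measured compounds:
compound 1 `O=C(CN(c1nc(Cl)nc2[nH]cnc12)C1CC1)N[C@@H](CC(=O)OCc1ccccc1)C(=O)OCc1ccccc1`: 22.4%
compound 2 `O=C(CN(c1ncnc2c1ncn2C1CCCCO1)C1CC1)N[C@@H](CC(=O)OCc1ccccc1)C(=O)OCc1ccccc1`: 38.2%
compound 3 `CC(C)(C)OC(=O)NCCCC[C@H](NC(=O)CN(c1ncnc2c1ncn2C1CCCCO1)C1CC1)C(=O)OCc1ccccc1`: 32.7%

In a functional assay on the whole organism (Tail, strain ICR) with Mus musculus as the target, in the tail flick test, with a stated time of 60 min, at a dose of 25 umol/kg by the oral route (a higher number here means a stronger effect of the compound at the dose given, a lower number a weaker effect), compound 1 stands lowest of the three numbers. Its nearest neighbour is compound 3, higher by an amount beyond the scatter, and the furthest is compound 2, higher by an amount also beyond the scatter.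

Compound 4 `NC(=O)C[C@H](NC(=O)CN(c1nc(Cl)nc2[nH]cnc12)C1CC1)C(=O)OCc1ccccc1` derives from compound 1 by one change: amino in place of benzyloxy on a carbonyl carbon.

For the measured compounds named here, the only measured step that touches the side chain is a number 5.5 percentage points lower from compound 2 to compound 3 (within the scatter), where the whole benzyloxycarbonyl group gave way to a different chain; that step stayed within the scatter. Going by the values given here, no measured pair exchanges benzyloxy for amino on a carbonyl carbon, and compounds 2 and 3 carry a core that differs from that of compound 1, so they bear on the question only loosely. Given that the one related step was flat, the expected step in this assay is a number 1.6 percentage points higher from compound 1 to compound 4 (within the scatter), none beyond the scatter. Compound 4 is therefore estimated at 24%, with a range from 10% to 40%.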

Compound 4, a percentage reported as activity, at one dose (the size of the read-out at that dose, not a potency): 36.4%
Compound 4: the middle estimate sits 12.4 percentage points below what was measured; low and high end bracket the measured number.
By their numbers in this assay, from the lowest: compound 1; then compounds 3, 4 and 2 (each within the scatter of the next).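

In this assay, amino in place of benzyloxy on a carbonyl carbon gives a number 14 percentage points higher from compound 1 to compound 4 (beyond the scatter), which shows that this side chain can shift the read-out on the core of compound 1, something the earlier step of a number 5.5 percentage points lower from compound 2 to compound 3 (within the scatter), made on another core, did not show. The benzyloxy group, with its six-membered aromatic ring of carbon only, is therefore not needed for this effect at the dose given, and the much smaller amino group does not lessen it. Nothing available explains this step.

The compounds shown leave open how a carboxylic acid or a methylamide would read at this carbonyl carbon. They also leave open whether the same change would give a similar step on the core of compound 2.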